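Trimming the Amide Terminus of a Piperazine Dopamine Ligand

The compounds below may be only part of what the source reports. "The series", "measured", "known", "first", "only" and "open" are said of these compounds alone.

Compound 1 `CC(C)(C)C(=O)NCCCCN1CCN(c2ccccc2Cl)CC1`: 79.4 nM
Compound 2 `CC(C)(C)C(=O)NCCCCN1CCN(c2ccc(Cl)cc2)CC1`: 12.6 nM
Compound 3 `COc1cc(Cl)ccc1N1CCN(CCCCNC(=O)C(C)(C)C)CC1`: 15.9 nM

In an assay on HEK293 cells for binding affinity to D(4) dopamine receptor (Homo sapiens), read by radioligand binding (a lower number here means a stronger inhibitor, a higher number a weaker inhibitor), compound 2 gives 12.6 nM, the lowest of the three numbers. The step of a 1.3-fold higher number from compound 2 to compound 3 (0.10 log units; within the scatter) stays within the scatter, whereas the step of a 6.3-fold lower number from compound 1 to compound 2 (0.80 log units; beyond the scatter) lies beyond it. Compound 4 `CC(=O)NCCCCN1CCN(c2ccc(Cl)cc2)CC1` differs from compound 2 by methyl in place of tert-butyl on a carbonyl carbon. Within the data shown here, neither measured step touches this end of the molecule; both alter the aryl ring, so no measured step bears directly on the change. With nothing to point one way, only a small step in this assay is expected, if any beyond the scatter. Compound 4 is therefore estimated at 25 nM, within 6 nM to 100 nM. That estimate corresponds to an expected step of a 2.0-fold higher number from compound 2 to compound 4 (0.30 log units; within the scatter).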

Compound 4, inhibition constant: 1260 nM
Compound 4: middle estimate off by 50-fold (1.70 log units), on the low side; measured number outside the range, above it.
By their numbers in this assay, from the lowest: compounds 2 and 3 (each within the scatter of the next); then compound 1; then compound 4.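

Among these compounds, the amide terminus, untouched by the earlier steps, proves highly sensitive in this assay. Methyl in place of tert-butyl on a carbonyl carbon gives a 100-fold higher number from compound 2 to compound 4 (2.00 log units; beyond the scatter), a larger step than the change on the aryl ring, a 6.3-fold lower number from compound 1 to compound 2 (0.80 log units; beyond the scatter), even though the two groups count the same hydrogen-bond donors, acceptors and net charge. No measurement here accounts for this step. As far as these compounds go, whether ethyl or isopropyl on the carbonyl carbon would give a number nearer that of compound 2 or that of compound 4 stays open. Also open, from the compounds shown here alone, is whether the same change would give a step of similar size on compound 1 or compound 3.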